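Does moving one hydroxyl change a weak inhibitor?

The compounds below may be only part of what the source reports. "The series", "measured", "known", "first", "only" and "open" are said of these compounds alone.

In a functional assay on MIA PaCa-2 cells (Homo sapiens) for inhibition, read by MTT assay, with a stated time of 72 h (a higher number here means a weaker inhibitor, a lower number a stronger inhibitor), compound 1 (`COc1cc(NC(C)CCCNC(=O)NNC(=O)Nc2ccc(C(F)(F)F)cc2)c2ncccc2c1`) gives 19000 nM and compound 3 (`COc1cc(NC(C)CCCNC(=O)NNC(=O)Nc2cccc(C(F)(F)F)c2)c2ncccc2c1`) gives 5600 nM as its reading. Compound 2 (`COc1cc(NC(C)CCCNC(=O)Nc2cccc(O)c2)c2ncccc2c1`) reads 46000 nM and so has the highest number of the three. Its gap to each of the others lies beyond the scatter, which makes it the weakest inhibitor of this small group.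

Compound 4 (`COc1cc(NC(C)CCCNC(=O)Nc2ccc(O)cc2)c2ncccc2c1`) differs from it in one place, with 4-hydroxyphenyl in place of 3-hydroxyphenyl on an amide-type nitrogen. Among the compounds with values here, no measured pair moves a hydroxyl group. The closest evidence is a 3.4-fold lower number from compound 1 to compound 3 (0.53 log units; beyond the scatter) when 3-(trifluoromethyl)phenyl replaces 4-(trifluoromethyl)phenyl. That swap runs the opposite way to the one here, and it involves another group on a different chain, so it is only a loose guide.

Taking a 3.4-fold lower number from compound 1 to compound 3 (0.53 log units; beyond the scatter) in reverse as a weak hint, a small rise in the number is expected in this assay for the new compound, though a result within the scatter would be no surprise. This expectation amounts to a 1.4-fold higher number from compound 2 to compound 4 (0.15 log units; within the scatter) as an estimated step. For compound 4 the estimate is 65000 nM with an expected range from 25000 nM to 150000 nM on this evidence.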

Compound 4, half-maximal inhibitory concentration: 57000 nM
Beside the measured number, compound 4's estimate is 1.1-fold (0.06 log units) above it; the range from low to high includes it.
By their numbers in this assay, from the lowest: compound 3; then compound 1; then compounds 2 and 4 (each within the scatter of the next).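

In this assay the exchange of 3-hydroxyphenyl for 4-hydroxyphenyl on the amide-type nitrogen gives a 1.2-fold higher number from compound 2 to compound 4 (0.09 log units; within the scatter) and therefore no readable change, so this hydroxyl can occupy either named place with the same result in this assay. Within the data shown here, the earlier compounds could not show this, since their only single-place step concerns trifluoromethyl on a different chain and runs the other way, as a 3.4-fold lower number from compound 1 to compound 3 (0.53 log units; beyond the scatter) shows, and that step lies beyond the scatter while the hydroxyl step does not. The two pairs together show that the effect of such an exchange is not the same for every group and chain, but no measurement given here accounts for the difference between them.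

As far as these compounds go, what remains open is whether the same flat result would hold for an amine or a carboxylic acid in place of the hydroxyl on this ring. It is also unknown whether the hydroxyl exchange would stay within the scatter on the longer chain carried by compound 1 and compound 3, where the trifluoromethyl exchange did not.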